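The source may hold more compounds than are shown below. What is called first, only, known or untested is meant among the compounds shown, and "the series" means these compounds.

Measured compounds and their numbers:

- compound 1 `N=C(N)NCCCOc1ccc(CNc2nc3ccc(Oc4cccc(C(F)(F)F)c4)cc3s2)cc1`: 130000 nM
- compound 2 `CN(Cc1ccc(OCCCNC(=N)N)cc1)c1nc2ccc(Oc3cccc(C(F)(F)F)c3)cc2s1`: 202000 nM

In an assay on SH-SY5Y cells for inhibition of Voltage-dependent N-type calcium channel subunit alpha-1B (Homo sapiens), read by FLIPR and calcium flux, with stated times of 600 s and 300 s, in the presence of a further agent that is not named here (on this read-out lower numbers stand for stronger inhibition and higher numbers for weaker inhibition), compound 1 gives 130000 nM. For the measured compounds named here, only one other compound has been measured, compound 2, and the step of a 1.6-fold higher number from compound 1 to compound 2 (0.19 log units; within the scatter) lies within the scatter, so the two numbers cannot be told apart, and compound 1 is simply one of two closely placed values, both very weak.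

Compound 3 `N=C(N)NCCCOc1ccc(CNc2nc3ccc(Oc4ccc(O)cc4)cc3s2)cc1` has not yet been measured. It differs from compound 1 by 4-hydroxyphenyl in place of 3-(trifluoromethyl)phenyl on an oxygen on an aromatic ring. Going by the values given here, the one measured step, from compound 1 to compound 2, concerns a methyl on a nitrogen elsewhere in the molecule, and it does not touch the part that changes here, so nothing measured bears directly on this change. Among the compounds with values here, with no step of this kind to lean on, the expectation for compound 3 is a step of about a 1.2-fold higher number from compound 1 to compound 3 (0.06 log units; within the scatter), with no confident direction and a wide range around it. Compound 3 is therefore estimated at 150000 nM, within a range from 40000 nM to 600000 nM.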

Compound 3, half-maximal inhibitory concentration: 253000 nM
Compound 3: the middle estimate sits 1.7-fold (0.23 log units) below what was measured; low and high end bracket the measured number.
By their numbers in this assay, from the lowest: compounds 1, 2 and 3 (each within the scatter of the next).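

In this assay, replacing 3-(trifluoromethyl)phenyl with 4-hydroxyphenyl on an oxygen on an aromatic ring gives a 1.9-fold higher number from compound 1 to compound 3 (0.29 log units; within the scatter), so the two compounds cannot be told apart. For the compounds shown here, this is the first measured change at this position, and it is a substantial one: the fluorine atoms leave, an oxygen enters, the count goes from 0 hydrogen-bond donors and 0 acceptors to 1 of each, and the substituent's place on the ring changes too, yet the number shows no change beyond the usual scatter. Nothing available here explains this result.

Going by these compounds alone, these compounds do not show whether any group on this oxygen can shift the number beyond the scatter, since this position has been tested with only one pair, in which the identity of the substituent and its place on the ring change together. A plain phenyl, 4-(trifluoromethyl)phenyl, 3-hydroxyphenyl or a phenyl ring carrying an amine or a carboxylic acid would help to separate those two changes and show how far this position can move the number.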